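This account rests on a few compounds, and the source may have more. Where it says the series, first, only, none or still open, it means among the compounds named here.

Measured in a functional assay on MDA-MB-231 cells (Homo sapiens) for cytotoxicity, read by MTT assay, with a stated time of 72 h; on this read-out higher numbers stand for weaker inhibition and lower numbers for stronger inhibition:
- compound 1 `CC1(C)OCC(Cn2cc(Cn3c4c(c5ccccc53)C(=O)c3c[n+]([O-])c5ccccc5c3C4=O)nn2)O1`: 230 nM
- compound 2 `CC1(C)O[C@@H](CO)[C@H](Cn2cc(Cn3c4c(c5ccccc53)C(=O)c3c[n+]([O-])c5ccccc5c3C4=O)nn2)O1`: 680 nM

Compound 2 has the higher of the two numbers. Compound 3 `CC1(C)OC[C@@H](Cn2cc(Cn3c4c(c5ccccc53)C(=O)c3c[n+]([O-])c5ccccc5c3C4=O)nn2)O1` is the next to be measured, and the change is 2,2-dimethyl-1,3-dioxolan-4-yl in place of 5-(hydroxymethyl)-2,2-dimethyl-1,3-dioxolan-4-yl on a saturated chain carbon bound to an aromatic nitrogen. Among the compounds with values here, the one measured step bearing on this is a 3.0-fold higher number from compound 1 to compound 2 (0.47 log units; beyond the scatter), which is modest but beyond the scatter and involves the same two groups, in the opposite sense. Compound 3 carries the group of compound 1, with its stereocentre defined, and the data do not show what that stereocentre alone does. A step of similar size towards a lower number is therefore expected in this assay. The expected step is a 2.8-fold lower number from compound 2 to compound 3 (0.45 log units; beyond the scatter). Compound 3 is estimated at 240 nM, with an expected range of 110 nM to 500 nM.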

Compound 3, half-maximal inhibitory concentration: > 1000 nM
Compound 3 gave a limit, no number; the forecaster's own chance of this, stated with the estimate: 1%; middle value at least 4.1-fold (0.61 log units) away from the limit.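

In this assay compound 3 gives a limit and not a number: the limit of > 1000 nM in this assay, at which 1 of the 3 values shown sits.

Removing the hydroxymethyl does not reverse the earlier step at this position, which now reads an at least 1.4-fold higher number from compound 2 to compound 3 (0.16 log units; that floor lies within the scatter). With the same atoms and bonds, the change reads an at least 4.3-fold higher number from compound 1 to compound 3 (0.63 log units; beyond the scatter), so the 2,2-dimethyl-1,3-dioxolan-4-yl group cannot be read without its drawn configuration: the fact that one of compounds 1 and 3 is drawn with a defined configuration and the other without, at the place where they differ

On these data alone, the exact number for compound 3 and the effect of the opposite configuration remain open. Also open, as far as these compounds go, is how an amine or a carboxylic acid in place of this group would read out on a saturated chain carbon bound to an aromatic nitrogen.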